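The source may report more compounds than this note shows. Statements on the series, on what has been measured and on what is new or still open speak of the compounds shown alone.

Measured compounds and values in a functional assay on A549 cells (Homo sapiens) for antiproliferative activity, read by MTT assay, with a stated time of 48 h; on this read-out lower numbers stand for stronger inhibition and higher numbers for weaker inhibition:
- compound 1, `N#CC1=C(N)Oc2c(c3nc4ccccc4nc3c3ccccc23)C12C(=O)N(Cc1cnnn1-c1ccc(Br)cc1)c1ccccc12`: 44300 nM
- compound 2, `Cc1ccc(-n2nncc2CN2C(=O)C3(C(C#N)=C(N)Oc4c3c3nc5ccccc5nc3c3ccccc43)c3ccccc32)cc1C`: a limit of the assay, > 50000 nM
- compound 3, `CCc1ccccc1-n1nncc1CN1C(=O)C2(C(C#N)=C(N)Oc3c(N)cc4nc5ccccc5nc4c32)c2ccccc21`: 24600 nM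

Compound 3 gives the lowest of the two numbers shown in this assay; the nearest is compound 1, a gap within the scatter, so no order between them is claimed. Compound 2 sits at the limit (the limit of > 50000 nM in this assay, at which 1 of the 3 values shown sits), so only a limit is known for it.

Compound 4, `N#CC1=C(N)Oc2c(N)cc3nc4ccccc4nc3c2C12C(=O)N(Cc1cnnn1-c1c(F)cccc1F)c1ccccc12`, differs from compound 3 in one place: 2,6-difluorophenyl in place of 2-ethylphenyl on an aromatic nitrogen. For the measured compounds named here, the one measured step that touches the same position, the aryl group on the aromatic nitrogen, is an at least 1.1-fold higher number from compound 1 to compound 2 (0.05 log units; that floor lies within the scatter), which swaps one aryl for another there and gives a floor that lies within the scatter. Going by the values given here, no step exchanges a 2-ethylphenyl for a 2,6-difluorophenyl, so the expectation for the aryl exchange here rests on that single step and is that nothing beyond the scatter should follow. Compound 4 is therefore expected to sit near compound 3, with an expected step of a 1.1-fold higher number from compound 3 to compound 4 (0.02 log units; within the scatter), at an estimated 26000 nM and a range from 10000 nM to 60000 nM in this assay.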

Compound 4, half-maximal inhibitory concentration: > 50000 nM
Compound 4 ended at the assay's limit (the forecaster's own chance of this, stated with the estimate: 25%); middle value at least 1.9-fold (0.28 log units) away from the limit.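

On the core of compound 3, the aryl exchange on an aromatic nitrogen in this assay gives an at least 2.0-fold higher number from compound 3 to compound 4 (0.30 log units; that floor lies within the scatter), so this position can now be read on a second core, beyond the earlier step of an at least 1.1-fold higher number from compound 1 to compound 2 (0.05 log units; that floor lies within the scatter). On these data alone, the new step is again only a floor within the scatter, so it shows no change beyond the scatter, and the true size of the step stays unknown. Compound 4 now shares the limit with compound 2, which leaves the upper end of the series unresolved: the limit of > 50000 nM in this assay, at which 2 of the 4 values shown sit.

As far as these compounds go, how far compound 2 and compound 4 lie past that limit remains open. Also open, from the compounds shown here alone, is whether a single fluorine, a longer chain in place of ethyl, or an amine on the phenyl ring would hold a readable number like that of compound 3, 24600 nM.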